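Benzyl for Phenyl on the Sulfonyl Sulfur

A few compounds are considered here, and "the series" means these few. Any claim that something is new, unique, unknown or untested is made for them only; others in the source may bear on it.

Three compounds have been measured in an assay on cells for displacement of a labelled ligand from prostaglandin E2 receptor EP4 subtype (Homo sapiens), read by scintillation counting; a higher number here means a weaker inhibitor, a lower number a stronger inhibitor:

Compound 1, `CCCS(=O)(=O)NC(=O)c1cc(COc2ccc(-c3ccc(OC)cc3)cc2)c(C)o1`, gives 5 nM.
Compound 2, `COc1ccc(-c2ccc(OCc3cc(C(=O)NS(=O)(=O)c4ccc(C)cn4)oc3C)cc2)cc1`, gives 15 nM.
Compound 3, `COc1ccc(-c2ccc(OCc3cc(C(=O)NS(=O)(=O)c4ccccc4)oc3C)cc2)cc1`, gives 5 nM.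

Compound 3 stands level with compound 1 and together with it at the lowest number of the three; no change at the digits printed from compound 1 to compound 3 (within the scatter). Compound 2 is the outlier, as a 3.0-fold lower number from compound 2 to compound 3 (0.48 log units; beyond the scatter) shows.

Compound 4, `COc1ccc(-c2ccc(OCc3cc(C(=O)NS(=O)(=O)Cc4ccccc4)oc3C)cc2)cc1`, has not been measured. It differs from compound 3 in one place: benzyl in place of phenyl on a sulfonyl sulfur. Within the data shown here, two measured steps bear on this position. The move from propyl to phenyl gave no change at the digits printed from compound 1 to compound 3 (within the scatter), while the move from propyl to 5-methylpyridin-2-yl gave a 3.0-fold higher number from compound 1 to compound 2 (0.48 log units; beyond the scatter). Benzyl itself has no measured neighbour, so the change is judged only from the tolerance this position has shown so far. The expected step is small, probably within the scatter, with a slight lean toward a higher number: a 1.4-fold higher number from compound 3 to compound 4 (0.15 log units; within the scatter). Compound 4 is therefore estimated at 7 nM, between 3 nM and 20 nM.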

Compound 4, inhibition constant: 3 nM
Compound 4: middle estimate off by 2.3-fold (0.37 log units), on the high side; the measured number falls inside the stated range.
By their numbers in this assay, from the lowest: compounds 4, 1 and 3 (each within the scatter of the next); then compound 2.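

In this assay, benzyl on the sulfonyl sulfur fits the tolerance seen so far, with a 1.7-fold lower number from compound 3 to compound 4 (0.22 log units; within the scatter) against phenyl and a 1.7-fold lower number from compound 1 to compound 4 (0.22 log units; within the scatter) against propyl, both within the scatter. The position therefore accepts a benzyl group as well as a phenyl group on the sulfur, and only the 5-methylpyridin-2-yl group of compound 2 goes against this, with a 5.0-fold lower number from compound 2 to compound 4 (0.70 log units; beyond the scatter) beyond the scatter. Nothing available explains why these groups give such similar numbers or why compound 2 stands apart.

As far as these compounds go, whether the tolerance extends to a longer chain such as 2-phenylethyl, or to a substituted benzyl such as 4-methoxybenzyl, remains open. Unsubstituted pyridin-2-yl and 4-methylphenyl would be needed to separate the roles of the ring nitrogen and the methyl group in compound 2.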